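Swapping the side-chain heterocycle in a dihydropyridine series

The source may hold more compounds than are shown below. What is called first, only, known or untested is meant among the compounds shown, and "the series" means these compounds.

Measured so far:
compound 1 `CCO/C(O)=C1\C(COCCNc2n[nH]c(N)n2)=NC(C)=C(C(=O)OC)C1c1cccc(Cl)c1Cl`, 6.31 nM
compound 2 `CCO/C(O)=C1\C(COCCNc2n[nH]c(N)n2)=NC(C)=C(C(=O)OC)C1c1cccc(C(F)(F)F)c1Cl`, 3.98 nM

In a functional assay (aorta) with Rattus norvegicus as the target (a higher number here means a weaker inhibitor, a lower number a stronger inhibitor), compound 1 gives the highest of the two numbers, with compound 2 the nearest at a 1.6-fold lower number from compound 1 to compound 2 (0.20 log units; within the scatter). Compound 3 `CCO/C(O)=C1\C(COCCNc2cc(Cl)ncn2)=NC(C)=C(C(=O)OC)C1c1cccc(Cl)c1Cl` differs from compound 1 in that (6-chloropyrimidin-4-yl in place of 5-amino-1H-1,2,4-triazol-3-yl on an amine nitrogen). Within the data shown here, the only measured step, from compound 1 to compound 2, changes a group on the aromatic ring and not the amine nitrogen, so no measured step bears on this change. With nothing to guide the direction, compound 3 is expected to give 10 nM, within 2 nM to 50 nM, which is an estimated step of a 1.6-fold higher number from compound 1 to compound 3 (0.20 log units; within the scatter).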

Compound 3, half-maximal inhibitory concentration: 12.6 nM
For compound 3 the middle estimate is 1.3-fold (0.10 log units) below the measured one; the measured number falls inside the stated range.
By their numbers in this assay, from the lowest: compounds 2, 1 and 3 (each within the scatter of the next, the first and the last beyond it).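

In this assay, 6-chloropyrimidin-4-yl in place of 5-amino-1H-1,2,4-triazol-3-yl on the amine nitrogen gives a 2.0-fold higher number from compound 1 to compound 3 (0.30 log units; within the scatter) and so stays within the scatter. This position therefore accepts a six-membered aromatic ring with no hydrogen-bond donors as well as a five-membered one with donors, at numbers of similar size. Nothing measured explains this result. Still open, going by these compounds, is whether a plain phenyl ring, a simple amine or a carboxylic acid would serve on this chain. Also open, on these data alone, is how 6-chloropyrimidin-4-yl behaves alongside the trifluoromethyl group of compound 2.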